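Demethylation of the anilino nitrogen across two stilbene cores

The compounds below may be only part of what the source reports. "The series", "measured", "known", "first", "only" and "open" are said of these compounds alone.

Measured compounds:
compound 1, `CN(C)c1ccc(/C=C/c2c(Cl)cccc2Cl)cc1`, 214 nM
compound 2, `CNc1ccc(/C=C/c2c(Cl)cccc2Cl)cc1`, 50.1 nM
compound 3, `CN(C)c1ccc(/C=C/c2c(F)cccc2Cl)cn1`, 4.7 nM

In a functional assay on LS174T cells (Homo sapiens) for antiproliferative activity (on this read-out lower numbers stand for stronger inhibition and higher numbers for weaker inhibition), compound 1 gives 214 nM, and compound 2 gives 50.1 nM. Within the data shown here, the one change between them, (hydrogen in place of methyl on a nitrogen on an aromatic ring), produced a 4.3-fold lower number from compound 1 to compound 2 (0.63 log units; beyond the scatter). Compound 3 carries a different core; how it differs from compound 1 is not broken down here. Compound 3 gives 4.7 nM, the lowest of the three numbers, and compound 2 stands nearest to it.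

Compound 4, `CNc1ccc(/C=C/c2c(F)cccc2Cl)cn1`, is not yet measured. It differs from compound 3 by hydrogen in place of methyl on a nitrogen on an aromatic ring, the same change that separates compound 1 from compound 2. If the step seen in a 4.3-fold lower number from compound 1 to compound 2 (0.63 log units; beyond the scatter) carries over to the core of compound 3, compound 4 is expected to give 1.5 nM, with 0.5 nM to 5 nM as the likely span. Among the measured compounds shown here, that expectation amounts to a 3.1-fold lower number from compound 3 to compound 4 (0.50 log units; beyond the scatter), and rests only on the single earlier pair. Compound 4 is estimated to fall slightly short of a full repeat of that step because compound 3 already gives 4.7 nM, a low number where such gains are harder to measure.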

Compound 4, half-maximal inhibitory concentration: 4 nM
Compound 4: middle estimate off by 2.7-fold (0.43 log units), on the low side; the measured number falls inside the stated range.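

In this assay, hydrogen in place of methyl on the nitrogen gave a 1.2-fold lower number from compound 3 to compound 4 (0.07 log units; within the scatter), so on this core the change leaves no difference that can be told from the scatter. Set beside the earlier step, the change did not carry over in size from one core to the other: the same change on two cores in this assay, a 4.3-fold lower number (0.63 log units; beyond the scatter) from compound 1 to compound 2 and a 1.2-fold lower number (0.07 log units; within the scatter) from compound 3 to compound 4, 3.6-fold (0.56 log units) apart, beyond the scatter of two such steps. This shows that the step seen on the core of compound 1 cannot be assumed to hold on another core in this series, but the two cores differ in more than one place, and the pairs shown do not tell which difference goes with the gap or how the change would behave on a third core.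

Going by these compounds, it remains open how an ethyl group or a longer chain on that nitrogen, or a free amino group carrying two hydrogens, would read in this assay. Among these compounds, each core also offers only one pair, in this one cell assay, so it is open whether the gap would recur on other cores or in other cell lines.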